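Thiophene in place of methyl on a Chk2 kinase core

The source may report more compounds than this note shows. Statements on the series, on what has been measured and on what is new or still open speak of the compounds shown alone.

Measured compounds:
compound 1 `Cc1cc2[nH]nc(N)c2c(=O)[nH]1`: 27%
compound 2 `COc1cccc(-c2cc3[nH]nc(N)c3c(=O)[nH]2)c1`: 52%
compound 3 `CN1CCN(c2ccc(-c3cc4[nH]nc(N)c4c(=O)[nH]3)cc2)CC1`: 68%

Of the compounds shown here, three sharing one core have been tested in an assay on isolated protein for inhibition of serine/threonine-protein kinase Chk2 (Homo sapiens), read by mobility shift assay, tested at 30 uM; a higher number here means more inhibition at the concentration tested (going by the name of the read-out), a lower number less inhibition. Compound 1 gives the lowest of the three numbers in this assay, 27%. Compound 2 carries a methoxyphenyl group where compound 1 carries a methyl. Compound 2 gives 52%, beyond the usual scatter above compound 1. Compound 3, with a methylpiperazinylphenyl group at that position, gives 68%, the furthest from compound 1 and also beyond the scatter.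

Compound 4 `Nc1n[nH]c2cc(-c3cccs3)[nH]c(=O)c12` has not yet been measured. It differs from compound 1 in one place: thiophen-2-yl in place of methyl on an aromatic carbon. Both measured compounds that carry an aromatic ring in place of the methyl score higher than compound 1, so a rise beyond the scatter is expected for compound 4 as well, since compound 2 gives 52% with a ring of its own at the same place. The step from compound 1 to compound 4 is estimated as a number 23 percentage points higher from compound 1 to compound 4 (beyond the scatter). For compound 4 the expected result in this assay is 50%, with a likely range from 30% to 70%.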

Compound 4, a percentage reported as inhibition, at one concentration (the size of the read-out at that concentration, not a potency): 59%
Estimate against measurement, compound 4: 9 percentage points below; low and high end bracket the measured number.
By their numbers in this assay, from the lowest: compound 1; then compounds 2, 4 and 3 (each within the scatter of the next, the first and the last beyond it).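

In this assay, going by these compounds alone, thiophen-2-yl in place of methyl gives a number 32 percentage points higher from compound 1 to compound 4 (beyond the scatter), the first step in this set that swaps the methyl for an aromatic ring with nothing further attached. Compound 2 and compound 3 each carry an extra group on their ring, yet compound 4 lies within the usual scatter of both, so a large rise at this position does not require such a group. Nothing available explains why this change raises the inhibition.

From the compounds shown here alone, whether an aromatic ring is needed at all remains open, as a cyclohexyl ring or a longer chain such as butyl at the same place would show. Going by these compounds, how plain phenyl or furan-2-yl compares with thiophen-2-yl also remains open.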